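Pyridin-3-yl in place of 1,3,5-trimethyl-1H-pyrazol-4-yl

The source may hold more compounds than are shown below. What is called first, only, known or untested is meant among the compounds shown, and "the series" means these compounds.

Compound 3 `Cc1cc(C)c(-c2c(C)nn(C)c2C)cc1NC(=O)c1ccc(OCc2ccccn2)cc1` stands at a limit in a physicochemical assay for lipophilicity; on this read-out higher numbers stand for higher lipophilicity and lower numbers for lower lipophilicity: the value for compound 3 is > 3, a limit of the assay and not a number. Compound 1 `Cc1cc(C)c(-c2nc3ccccc3[nH]2)cc1NC(=O)c1ccc(OCc2ccccn2)cc1` is reported in this assay only as the limit > 3.5. Compound 2 `Cc1csc(-c2cc(NC(=O)c3ccc(OCc4ccccn4)cc3)c(C)cc2C)n1` likewise gives in this assay the limit > 3. Two of the three values sit at the limit of > 3 in this assay, at which 2 of the 3 values shown sit, and one at the limit of > 3.5 in this assay, at which 1 of the 3 values shown sits, so the steps among them, a step that the two limits leave unreadable from compound 1 to compound 2, a step that the two limits leave unreadable from compound 1 to compound 3 and a step that the two limits leave unreadable from compound 2 to compound 3, cannot be read in size or direction. Compound 4 `Cc1cc(C)c(-c2cccnc2)cc1NC(=O)c1ccc(OCc2ccccn2)cc1` differs from compound 3 in one place: pyridin-3-yl in place of 1,3,5-trimethyl-1H-pyrazol-4-yl on an aromatic carbon. Among the compounds with values here, none of the measured steps bears on this change, and the three limits give no size to carry over, so no step beyond the scatter can be argued for in either direction. Compound 4 is therefore estimated to lie near the same limits at 3.2, within 2.6 to 3.8, an expected step that the limit leaves unreadable from compound 3 to compound 4 that stays within the scatter.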

Compound 4, distribution coefficient: > 3
Compound 4: only a limit was reported; the forecaster's own chance of this, stated with the estimate: 50%; the middle value does not contradict the limit.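

In this assay compound 4 gives > 3 as a limit of the assay and not a number. Its steps from compound 1, compound 2 and compound 3 therefore cannot be read in size or direction: the limit of > 3 in this assay, at which 3 of the 4 values shown sit.

The compounds shown leave open whether the four groups on the aromatic carbon differ at all in this assay or not.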